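Swapping carbamoyl for methoxy: compound 3 in microsomes

The compounds below may be only part of what the source reports. "The series", "measured", "known", "first", "only" and "open" are said of these compounds alone.

Compound 1 `Cc1c([C@H](C)Nc2nc(N)nc(N)c2C#N)c(-c2ccccc2)c(=O)n2cc(F)ccc12` gives 80% in an ADME assay on microsomes from liver (Homo sapiens), read by LC-MS, using NADPH, with a stated time of 30 min, tested at 1 uM; a lower number here means that less of the compound is left, a higher number that more of the compound is left. Compound 2 `C[C@H](Nc1nc(N)nc(N)c1C#N)c1c(-c2ccccc2)c(=O)n2cc(F)ccc2c1-c1ccc(C(N)=O)cc1` gives 105% in this assay, the higher of the two numbers, after a change of a number 25 percentage points higher from compound 1 to compound 2 (beyond the scatter). Compound 3 `COc1ccc(-c2c([C@H](C)Nc3nc(N)nc(N)c3C#N)c(-c3ccccc3)c(=O)n3cc(F)ccc23)cc1` differs from compound 2 by methoxy in place of carbamoyl on an aromatic carbon. Among the measured compounds shown here, no measured step touches this position; the only step known concerns another part of the core. Since nothing bears directly on it, compound 3 is expected to stay close to compound 2, with a step of a number 17 percentage points lower from compound 2 to compound 3 (beyond the scatter) being the estimate. Compound 3 is therefore expected to give about 88%, between 55% and 110%.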

Compound 3, percent of the compound remaining: 89%
The estimate for compound 3 lay 1 percentage points below the measured number; the measured number falls inside the stated range.
By their numbers in this assay, from the lowest: compounds 1 and 3 (each within the scatter of the next); then compound 2.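

In this assay, the change from 4-carbamoylphenyl to 4-methoxyphenyl gives a number 16 percentage points lower from compound 2 to compound 3 (beyond the scatter), so the group on this aromatic ring does affect how much compound is left. Methyl to 4-methoxyphenyl gives a number 9 percentage points higher from compound 1 to compound 3 (within the scatter), so the gain over methyl seen with 4-carbamoylphenyl is not shared by 4-methoxyphenyl. Nothing at hand accounts for this difference. The compounds shown leave open whether an amine or a carboxylic acid in this place would match the carbamoyl result, and how a plain phenyl without any such group would compare.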